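The compounds below may be only part of what the source reports. "The series", "measured", "known", "first", "only" and "open" are said of these compounds alone.

Working notes on the series

Compound 2 (`Cn1c(N2N=C(c3ccccc3)CC2c2ccc(F)cc2)nc(-c2ccccc2)c(C#N)c1=O`) stands at the lower of the two numbers measured in a functional assay on MDA-MB-231 cells (Homo sapiens) for antiproliferative activity, with a stated time of 72 h; a higher number here means a weaker inhibitor, a lower number a stronger inhibitor: in this assay compound 2 gives 11800 nM while compound 1 (`Cn1c(N2N=C(c3ccccc3)CC2c2ccc(Cl)cc2)nc(-c2ccccc2)c(C#N)c1=O`) gives 28000 nM in the same assay. Among the compounds with values here, the single step between measured compounds, a 2.4-fold lower number from compound 1 to compound 2 (0.38 log units; beyond the scatter), is a halogen exchange and does not touch the change now considered. Compound 3 (`Cc1ccc(C2=NN(c3nc(-c4ccccc4)c(C#N)c(=O)n3C)C(c3ccc(F)cc3)C2)cc1`) differs from compound 2 by methyl in place of hydrogen on an aromatic carbon on the phenyl attached to the ring carbon bearing the nitrogen double bond. Within the data shown here, no measured step shows a methyl entering for hydrogen, so nothing in the set bears directly on this change; the halogen step is only a rough indication of how much that part of the structure moves the number. The expectation for compound 3 is therefore no step beyond the scatter in this assay, as a 1.0-fold higher number from compound 2 to compound 3 (0.01 log units; within the scatter) expresses. Compound 3 is estimated at 12000 nM with a range from 4000 nM to 36000 nM in this assay.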

Compound 3, half-maximal inhibitory concentration: 5100 nM
Beside the measured number, compound 3's estimate is 2.4-fold (0.37 log units) above it, within the range that was stated.
By their numbers in this assay, from the lowest: compound 3; then compound 2; then compound 1.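

In this assay the change from phenyl to 4-methylphenyl gives a 2.3-fold lower number from compound 2 to compound 3 (0.36 log units; beyond the scatter) and so shows that this aryl group, identical in compound 1 and compound 2, can also move the number. A single added methyl, para to a large group, is enough to produce a modest step beyond the scatter, and compound 3 now has the lowest number of the three. Nothing at hand explains this step. 

On these data alone, it remains open whether a longer chain such as ethyl, or a methoxy group or an amine in the same place, would lower the number further or raise it. Within the data shown here, it is also open whether the methyl step would carry over to the chloro partner, compound 1, since the methyl has been seen only with the fluoro compound.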